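A Methoxy Added to Compound 2

The source may report more compounds than this note shows. Statements on the series, on what has been measured and on what is new or still open speak of the compounds shown alone.

In a functional assay on PC-3 cells (Homo sapiens) for cytotoxicity, read by MTT assay, with a stated time of 72 h (a lower number here means a stronger inhibitor, a higher number a weaker inhibitor), compound 2 `COc1ccc(/C=C/c2cc(C)n[nH]2)cc1` gives 8900 nM and stands between the other two measured compounds. Compound 1 `Cc1cc(/C=C/c2ccc(O)cc2)[nH]n1` is the weakest at 48100 nM and compound 3 `Cc1cc(/C=C/c2ccc(O)c(O)c2)on1` is the strongest at 3300 nM in this set. Compound 4 `COc1ccc(/C=C/c2cc(C)n[nH]2)cc1OC` differs from compound 2 by a methoxy in place of hydrogen on an aromatic carbon and has not yet been measured.

Within the data shown here, only one measured step bears on this change: a 5.4-fold lower number from compound 1 to compound 2 (0.73 log units; beyond the scatter) was modest and beyond the scatter. That step put methyl in place of hydrogen on an oxygen on an aromatic ring, so it is only an indirect guide. Among the measured compounds shown here, no measured step places a group on an aromatic carbon. Accordingly, no step beyond the scatter is expected in this assay and the estimate is a 1.3-fold lower number from compound 2 to compound 4 (0.10 log units; within the scatter) for this change. Compound 4 is estimated at 7000 nM with an expected range of 2500 nM to 20000 nM in this assay for its measurement.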

Compound 4, half-maximal inhibitory concentration: 12600 nM
Beside the measured number, compound 4's estimate is 1.8-fold (0.26 log units) below it, within the range that was stated.
By their numbers in this assay, from the lowest: compound 3; then compounds 2 and 4 (each within the scatter of the next); then compound 1.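

Placing a methoxy in place of hydrogen on an aromatic carbon, ortho to a methoxy group and meta to a group of 8 heavy atoms, gives a 1.4-fold higher number from compound 2 to compound 4 (0.15 log units; within the scatter) in this assay. Among these compounds, this is the first measured change on an aromatic carbon of this ring, and this position accepts a second methoxy with no change that can be told from the scatter, whereas the earlier change on the oxygen, a 5.4-fold lower number from compound 1 to compound 2 (0.73 log units; beyond the scatter), lay beyond it. Nothing shown offers an explanation for this result.

From the compounds shown here alone, on this aromatic carbon, only hydrogen and methoxy can be compared so far, so what an amine, a carboxylic acid or a longer chain such as ethoxy would do there remains open. It is also unknown whether the same added methoxy would behave alike on the core of compound 3.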